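Halogen exchange on the shared core: fluoro to bromo

A few compounds are considered here, and "the series" means these few. Any claim that something is new, unique, unknown or untested is made for them only; others in the source may bear on it.

Of the compounds shown here, two have been measured. Compound 1 `O=c1[nH]c(=O)n([C@@H]2O[C@@H]3COP(=O)(O)O[C@H]3[C@H]2O)cc1I` carries iodo on the aromatic carbon; in a functional assay on L1210 cells (Mus musculus) (on this read-out higher numbers stand for weaker inhibition and lower numbers for stronger inhibition), compound 1 gives 344 ug/mL. Among the measured compounds shown here, compound 2 `O=c1[nH]c(=O)n([C@@H]2O[C@@H]3COP(=O)(O)O[C@H]3[C@H]2O)cc1F` has fluoro at the same place; in this assay compound 2 gives 0.332 ug/mL, the lowest of the two numbers, with compound 1 as its only neighbour. For the measured compounds named here, the single step so far, a 1000-fold lower number from compound 1 to compound 2 (3.02 log units; beyond the scatter), is the whole evidence on halogen size at this carbon.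

Compound 3 `O=c1[nH]c(=O)n([C@@H]2O[C@@H]3COP(=O)(O)O[C@H]3[C@H]2O)cc1Br` is the next halogen: bromo in place of fluoro on an aromatic carbon. Bromo stands between fluoro and iodo in size, so the step from compound 2 should go back toward the number of compound 1, but no measured step tells how far. Going by the values given here, a large rise is expected, a 180-fold higher number from compound 2 to compound 3 (2.26 log units; beyond the scatter), because the only comparable step is a 1000-fold lower number from compound 1 to compound 2 (3.02 log units; beyond the scatter). Compound 3 is estimated at 60 ug/mL, within 5 ug/mL to 400 ug/mL.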

Compound 3, concentration for 50% inhibition: 294 ug/mL
Beside the measured number, compound 3's estimate is 4.9-fold (0.69 log units) below it; the range from low to high includes it.
By their numbers in this assay, from the lowest: compound 2; then compounds 3 and 1 (each within the scatter of the next).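

Among the three halogens shown at this aromatic carbon in this assay, fluoro alone stands apart (an 890-fold higher number from compound 2 to compound 3 (2.95 log units; beyond the scatter)), while bromo and iodo cannot be told apart (a 1.2-fold lower number from compound 1 to compound 3 (0.07 log units; within the scatter)). The read-out therefore does not fall in even stages from iodo through bromo to fluoro; across these three compounds, only the fluoro compound gives a low number. Nothing measured on these compounds bears on why fluoro parts from the other two halogens.

Where chloro falls, with fluoro or with bromo and iodo, stays open. So does the reading for hydrogen, methyl or trifluoromethyl on this same carbon, which would show whether the low number belongs to fluoro alone or also to other small groups.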